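Ethylamine in Place of Methylamine on a Second Core

The source may report more compounds than this note shows. Statements on the series, on what has been measured and on what is new or still open speak of the compounds shown alone.

Compound 1 `C=C(c1ccc(OC)cc1NC(=O)CNC)c1ccc(OC)c2c1C=CC(C)(C)O2`: 1010 nM
Compound 2 `C=C(c1cc(OC)c(OC)c(OC)c1)c1ccc(OC)cc1NC(=O)CNC`: 240 nM
Compound 3 `C=C(c1ccc(OC)cc1NC(=O)CNCC)c1ccc(OC)c2c1C=CC(C)(C)O2`: 2920 nM

All three were tested in a functional assay on MCF7 cells (Homo sapiens) for antiproliferative activity, read by MTT assay, with a stated time of 48 h; a higher number here means a weaker inhibitor, a lower number a stronger inhibitor. Compound 2 gives the lowest of the three numbers, with 240 nM; compound 1 gives 1010 nM and compound 3 gives 2920 nM. How the core of compound 2 differs from the core of compound 1 is not broken down here.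

Compounds 1 and 3 share a core and differ in one place: methyl in place of hydrogen on a saturated chain carbon bound to an amine nitrogen. That change produced a 2.9-fold higher number from compound 1 to compound 3 (0.46 log units; beyond the scatter), so the larger amine substituent went with a weaker inhibitor on this core.

Compound 4 `C=C(c1cc(OC)c(OC)c(OC)c1)c1ccc(OC)cc1NC(=O)CNCC` has not yet been measured in this assay. It stands to compound 2 exactly as compound 3 stands to compound 1, through the same change: methyl in place of hydrogen on a saturated chain carbon bound to an amine nitrogen. The places given for the two changes are the same word for word, so this is the same change made on a different core.

Given only one earlier example of this change, the expectation for compound 4 rests on it. The step from compound 2 to compound 4 is expected to resemble the step observed from compound 1 to compound 3, giving an estimated 2.9-fold higher number from compound 2 to compound 4 (0.46 log units; beyond the scatter). On that basis compound 4 is expected to give about 700 nM in this assay, likely between 300 nM and 1600 nM, since the change on the other core gave a 2.9-fold higher number from compound 1 to compound 3 (0.46 log units; beyond the scatter).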

Compound 4, half-maximal inhibitory concentration: 860 nM
Compound 4: middle estimate off by 1.2-fold (0.09 log units), on the low side; measured number inside the range.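

In this assay, replacing methylamino with ethylamino on the core of compound 2 gave a 3.6-fold higher number from compound 2 to compound 4 (0.55 log units; beyond the scatter), so the larger amine substituent again went with a weaker inhibitor. Set side by side, the steps on the two cores agree in direction and, within the scatter, in size: the same change on two cores in this assay, a 2.9-fold higher number (0.46 log units; beyond the scatter) from compound 1 to compound 3 and a 3.6-fold higher number (0.55 log units; beyond the scatter) from compound 2 to compound 4, 1.2-fold (0.09 log units) apart, within the scatter of two such steps For this pair of cores, then, the step measured on one core was a fair guide to the step on the other, but two examples in a single cell assay do not establish a general rule for the series, and they do not explain why the ethylamino compounds are the weaker ones.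

The compounds shown leave open whether the trend continues with a longer chain, as in propylamino, or reverses with a plain primary amine, which carries no carbon substituent on its nitrogen. They also leave open how a cyclic amine such as pyrrolidine would behave in place of methylamino, and whether the methylamino to ethylamino step would keep a similar size on a third core.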